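The compounds below may be only part of what the source reports. "The series", "measured", "known", "first", "only" and "open" are said of these compounds alone.

Three compounds share one core and differ only in the group carried on a saturated chain carbon bound to a sulfur. Compound 1 `N#Cc1c(N)nc(SCc2cccnc2)c(C#N)c1-c1ccc(OCC2CC2)cc1` carries a pyridin-3-yl there, and in an assay on CHO cells for displacement of a labelled ligand from adenosine receptor A1 (Homo sapiens), read by scintillation counting, with a stated time of 90 min (on this read-out higher numbers stand for weaker inhibition and lower numbers for stronger inhibition), compound 1 gives 67 nM. Compound 2 `N#Cc1c(N)nc(SCc2ccn[nH]2)c(C#N)c1-c1ccc(OCC2CC2)cc1` carries a 1H-pyrazol-5-yl, and in this assay compound 2 gives 552 nM, which is an 8.2-fold higher number from compound 1 to compound 2 (0.92 log units; beyond the scatter). Compound 3 `COC(=O)c1cccc(CSc2nc(N)c(C#N)c(-c3ccc(OCC4CC4)cc3)c2C#N)c1` carries a 3-(methoxycarbonyl)phenyl, and in this assay compound 3 gives 66 nM, the lowest of the three numbers, though a 1.0-fold lower number from compound 1 to compound 3 (0.01 log units; within the scatter) and an 8.4-fold lower number from compound 2 to compound 3 (0.92 log units; beyond the scatter). Compound 4 `N#Cc1c(N)nc(SCc2ncc[nH]2)c(C#N)c1-c1ccc(OCC2CC2)cc1` is not yet measured; its change from compound 3 is 1H-imidazol-2-yl in place of 3-(methoxycarbonyl)phenyl on a saturated chain carbon bound to a sulfur. The group that enters is closer in kind to the 1H-pyrazol-5-yl of compound 2 than to the group that leaves, so the measured step that bears most on it is the one that gave an 8.4-fold lower number from compound 2 to compound 3 (0.92 log units; beyond the scatter), here run roughly in reverse. Compound 4 is therefore expected in this assay to give about 500 nM, between 150 nM and 1500 nM, an estimated step of a 7.6-fold higher number from compound 3 to compound 4 (0.88 log units; beyond the scatter) toward weaker inhibition.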

Compound 4, inhibition constant: 235 nM
For compound 4 the middle estimate is 2.1-fold (0.33 log units) above the measured one, within the range that was stated.
By their numbers in this assay, from the lowest: compounds 3 and 1 (each within the scatter of the next); then compound 4; then compound 2.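

In this assay, the two five-membered rings are not interchangeable: 1H-imidazol-2-yl in place of 1H-pyrazol-5-yl gives a 2.3-fold lower number from compound 2 to compound 4 (0.37 log units; beyond the scatter), so at this carbon the arrangement of the ring atoms matters, not only the ring size. Even so, 1H-imidazol-2-yl does not reach the numbers of the six-membered ring groups, with a 3.6-fold higher number from compound 3 to compound 4 (0.55 log units; beyond the scatter) when it replaces 3-(methoxycarbonyl)phenyl and a 3.5-fold higher number from compound 1 to compound 4 (0.54 log units; beyond the scatter) when it replaces pyridin-3-yl. Among these four compounds, both five-membered rings therefore stand on the weaker side of both six-membered rings, and no compound goes against that.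

From the compounds shown here alone, whether a carboxylic acid in place of the methoxycarbonyl of compound 3, or a longer chain carrying the 1H-imidazol-2-yl, would move the number in either direction remains open. No supporting evidence accompanies these numbers to say why the rings differ.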